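Swapping the Substituted Amide Ring for Plain Phenyl

The compounds below may be only part of what the source reports. "The series", "measured", "known", "first", "only" and "open" are said of these compounds alone.

Of the compounds shown here, three sharing one core have been tested in a functional assay on HCT-15 cells (Homo sapiens) for inhibition, read by sulforhodamine B assay, with a stated time of 48 h; a higher number here means a weaker inhibitor of growth, a lower number a stronger inhibitor of growth. Compound 1 `O=C(Nc1cccc(-n2cc(-c3ccncc3)c(-c3ccc(Cl)c(O)c3)n2)c1)Nc1ccc(Cl)c(Cl)c1` gives 29600 nM. Compound 3 `O=C(Nc1cccc(-n2cc(-c3ccncc3)c(-c3ccc(Cl)c(O)c3)n2)c1)Nc1cc(C(F)(F)F)cc(C(F)(F)F)c1` gives 3520 nM. For compound 2 `COc1cc(-c2nn(-c3cccc(NC(=O)c4ccc(Cl)c(C(F)(F)F)c4)c3)cc2-c2ccncc2)ccc1Cl` this assay returned only a limit, > 32500 nM, so its place is known just as one sitting at the limit of > 32500 nM in this assay, at which 1 of the 3 values shown sits. Compound 4 `COc1cc(-c2nn(-c3cccc(NC(=O)c4ccccc4)c3)cc2-c2ccncc2)ccc1Cl` has not yet been measured; it differs from compound 2 by phenyl in place of 4-chloro-3-(trifluoromethyl)phenyl on a carbonyl carbon. Since compound 2 already sits at the limit > 32500 nM, no numbered step from it can be read off. The step that the limit leaves unreadable from compound 2 to compound 4 is expected to be none beyond the scatter, with a limit again the most likely report. Compound 4 is expected to give about 40000 nM, within the range 15000 nM to 100000 nM.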

Compound 4, concentration for total growth inhibition: > 100000 nM
Compound 4 gave a limit, no number (the forecaster's own chance of this, stated with the estimate: 70%); middle value at least 2.5-fold (0.39 log units) from the limit.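

In this assay, among the compounds shown here, compound 2 and compound 4 each returned only a limit, so no step between them can be read. On these data alone, whether phenyl or 4-chloro-3-(trifluoromethyl)phenyl on the carbonyl carbon gives stronger growth inhibition remains open.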